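The source may hold more compounds than are shown below. What is called first, only, known or untested is meant among the compounds shown, and "the series" means these compounds.

In an ADME assay on Raji cells (Homo sapiens) for cytotoxicity, with a stated time of 72 h (a higher number here means that more compound is needed for the effect, a lower number that less compound is needed), the measured compounds stand as follows:

Compound 1 `Cc1cc(NC(=O)Nc2ccccc2OC(F)(F)F)c2ccccc2n1` gives > 25000 nM, which is a limit of the assay and not a number.
Compound 2 `Cc1cc(NC(=O)Nc2cccc(C(N)=O)c2)c2ccccc2n1` gives > 25000 nM, again a limit and not a number.
Compound 3 `Cc1cc(NC(=O)Nc2cc(F)cc(F)c2)c2ccccc2n1` gives > 25000 nM, again a limit and not a number.

Compound 2 therefore stands where every measured compound of this small set stands: at the limit of > 25000 nM in this assay, at which 3 of the 3 values shown sit. Nothing on the numbers shown separates compound 2 from compound 1 or compound 3, and no step between any two of them can be given a size, so there is no measured step to lean on.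

The next compound to be tested is compound 4 `Cc1cc(NC(=O)Nc2cccc(Cl)c2)c2ccccc2n1`. It differs from compound 2 in one place: chloro in place of carbamoyl on an aromatic carbon. Within the data shown here, with no measured step to guide the expectation, the step is taken from the fact that all three measured compounds sit at the same limit of > 25000 nM in this assay, at which 3 of the 3 values shown sit: the change is expected to bring no shift beyond the scatter, a step that the limit leaves unreadable from compound 2 to compound 4. Compound 4 is thus expected to give about 30000 nM in this assay, within a range from 10000 nM to 100000 nM, and most probably to come back as a limit again.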

Compound 4, half-maximal effective concentration: 18000 nM
The estimate for compound 4 lay 1.7-fold (0.22 log units) above the measured number, and the stated range covers the measured number.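

Among these compounds, the change from carbamoyl to chloro on this aromatic carbon, meta to a large group, gives the first readable number in this assay. Its size can be given only as a floor: an at least 1.3-fold lower number from compound 2 to compound 4 (0.14 log units; that floor lies within the scatter), so this position may respond to the change, but the data do not establish a real shift. Compound 4 is the only one of the four compounds to have left the shared limit: the limit of > 25000 nM in this assay, at which 3 of the 4 values shown sit.

From the compounds shown here alone, whether the readable number belongs to chloro in particular, or whether a bromo group, an amine or a carboxylic acid at this place would also give one, stays open. Going by these compounds, how large the step really is also stays open, as it has a floor and no upper end.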